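The source may report more compounds than this note shows. Statements on the series, on what has been measured and on what is new or still open speak of the compounds shown alone.

In an assay on CHO-K1 cells for displacement of a labelled ligand from adenosine receptor A1 (Homo sapiens), read by scintillation counting, with a stated time of 60 min (a lower number here means a stronger inhibitor, a higher number a weaker inhibitor), compound 1 `Nc1nc(N/N=C/c2ccc(-c3ccc(Br)cc3)o2)nc2c1ncn2[C@@H]1O[C@H](CO)[C@@H](O)[C@H]1O` gives 4.5 nM. Among the compounds with values here, compound 2 `Nc1nc(N/N=C/c2cncs2)nc2c1ncn2[C@@H]1O[C@H](CO)[C@@H](O)[C@H]1O` gives in this assay 22 nM, the higher of the two numbers read so far; its nearest neighbour is compound 1, and the gap between them lies beyond the usual scatter. Compound 3 `Nc1nc(N/N=C/c2ccc(C(F)(F)F)cc2C(F)(F)F)nc2c1ncn2[C@@H]1O[C@H](CO)[C@@H](O)[C@H]1O` gives in this assay only a limit, > 10000 nM, and no number. Compound 4 `CCCCC/C=C/C=C/C=N/Nc1nc(N)c2ncn([C@@H]3O[C@H](CO)[C@@H](O)[C@H]3O)c2n1` is not yet measured in this assay. It differs from compound 2 in one place: a group of 9 heavy atoms (9 carbon; no ring) in place of a group of 5 heavy atoms (3 carbon, 1 nitrogen, 1 sulfur; one five-membered aromatic ring with 2 hetero atoms), on a carbon with a double bond to nitrogen. Both compounds with a read number, compound 1 and compound 2, carry a ring on that carbon, while compound 4 carries none, so the step from compound 2 to compound 4 is expected to be a weakening of a 3.2-fold higher number from compound 2 to compound 4 (0.50 log units; beyond the scatter). The estimate for compound 4 is 70 nM, with a range from 15 nM to 400 nM.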

Compound 4, inhibition constant: 2 nM
Beside the measured number, compound 4's estimate is 35-fold (1.54 log units) above it, and the stated range ends above it.
By their numbers in this assay, from the lowest: compound 4; then compound 1; then compound 2. At a limit, above all of these: compound 3.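

In this assay, replacing 1,3-thiazol-5-yl with the open chain of 9 carbon gives an 11-fold lower number from compound 2 to compound 4 (1.04 log units; beyond the scatter). The entering group has no ring and no hydrogen-bond acceptors, so neither is required on this carbon for a low number. Compound 3 gives only a limit, so no step to it can be read: the limit of > 10000 nM in this assay, at which 1 of the 4 values shown sits.

As far as these compounds go, what remains open is whether the low number depends on the chain's 2 double bonds or on its length. A saturated nonyl chain and a shorter hexyl chain at this place would separate the two.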